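Indazolyl in place of acetylphenyl: a pending step

A few compounds are considered here, and "the series" means these few. Any claim that something is new, unique, unknown or untested is made for them only; others in the source may bear on it.

Compound 2 `COc1cc(-c2ccnc3cc(-c4ccc(C(C)=O)cc4)nn23)cc(OC)c1OC` is the reference. In a functional assay on HCT-116 cells (Homo sapiens) for inhibition, read by CCK-8 assay, with a stated time of 48 h (a lower number here means a stronger inhibitor, a higher number a weaker inhibitor), compound 2 gives 4390 nM, the highest of the two numbers reported. Compound 3 `COc1cc(-c2ccnc3cc(-c4ccc(-c5cnn(C)c5)cc4)nn23)cc(OC)c1OC` gives 2110 nM in this assay. Compound 1 `COc1cc(-c2ccnc3cc(-c4ccc(C(C)(C)C)cc4)nn23)cc(OC)c1OC` gives only > 10000 nM in this assay, a limit and not a number; this is the limit of > 10000 nM in this assay, at which 1 of the 3 values shown sits. The measured steps are an at least 2.2-fold lower number from compound 1 to compound 2 (0.35 log units; beyond the scatter), an at least 4.7-fold lower number from compound 1 to compound 3 (0.67 log units; beyond the scatter) and a 2.1-fold lower number from compound 2 to compound 3 (0.32 log units; beyond the scatter). Compound 4 `COc1cc(-c2ccnc3cc(-c4ccc5cnn(C)c5c4)nn23)cc(OC)c1OC` carries 1-methyl-1H-indazol-6-yl in place of 4-acetylphenyl on an aromatic carbon. The step from compound 2 to compound 3, where an aromatic heterocycle replaced the acetyl group, is the nearest parallel and was modest. As far as these compounds go, a modest lowering is therefore expected, though the 1-methyl-1H-indazol-6-yl group of compound 4 is untested. Compound 4 is estimated at 2000 nM, within 700 nM to 6000 nM. That estimate means a 2.2-fold lower number from compound 2 to compound 4 (0.34 log units; beyond the scatter), expected to be modest.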

Compound 4, half-maximal inhibitory concentration: 2440 nM
For compound 4 the middle estimate is 1.2-fold (0.09 log units) below the measured one, within the range that was stated.
By their numbers in this assay, from the lowest: compounds 3, 4 and 2 (each within the scatter of the next, the first and the last beyond it). At a limit, above all of these: compound 1.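

In this assay, a fused ring group at this aromatic carbon is now shown: 1-methyl-1H-indazol-6-yl in place of 4-acetylphenyl gives a 1.8-fold lower number from compound 2 to compound 4 (0.26 log units; within the scatter), so this change cannot be separated from 4-acetylphenyl. In place of 4-(tert-butyl)phenyl, the same group gives an at least 4.0-fold lower number from compound 1 to compound 4 (0.61 log units; beyond the scatter). Compound 1 stands at a limit, not a number: the limit of > 10000 nM in this assay, at which 1 of the 4 values shown sits.

Open, as far as these compounds go, is whether an amine or a carboxylic acid on the group at this carbon would move the number clearly beyond compound 3 and compound 4. Also open, from the compounds shown here alone, is what the methyl on the indazole nitrogen contributes.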